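From Butyl to Cyclopentyl on the Sulfur

A few compounds are considered here, and "the series" means these few. Any claim that something is new, unique, unknown or untested is made for them only; others in the source may bear on it.

In an ADME assay on MT4 cells (Homo sapiens) for activation, read by MTT assay (on this read-out higher numbers stand for lower toxicity in this test and lower numbers for higher toxicity in this test), compound 1 (`CCCSc1nc(C(CC)c2c(F)cccc2F)c(C)c(=O)[nH]1`) gives > 3000 nM as a limit. Compound 2 (`CCCCSc1nc(C(CC)c2c(F)cccc2F)c(C)c(=O)[nH]1`) gives > 3000 nM as a limit too, so it has no exact standing. Going by the values given here, the one measured step (a step that the two limits leave unreadable from compound 1 to compound 2) offers no size to carry forward. Compound 3 (`CCC(c1nc(SC2CCCC2)[nH]c(=O)c1C)c1c(F)cccc1F`) has cyclopentyl in place of butyl on a sulfur and is otherwise unchanged. Among the compounds with values here, for compound 2 the only guide is the limit of > 3000 nM in this assay, at which 2 of the 2 values shown sit, and no size can be read from it. An estimated step (a step that the limit leaves unreadable from compound 2 to compound 3) no larger than the usual scatter is therefore expected in this assay in no set direction. Compound 3 is estimated at 5000 nM (expected range 2000 nM to 20000 nM) and may well be reported only as a limit.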

Compound 3, half-maximal cytotoxic concentration: 30000 nM
Compound 3: the middle estimate sits 6.0-fold (0.78 log units) below what was measured; the whole stated range lies below it.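

No size can be read for the steps from compound 1 or compound 2 to compound 3, because compound 1 and compound 2 stand only at a limit: the limit of > 3000 nM in this assay, at which 2 of the 3 values shown sit. The compounds shown leave open how much cyclopentyl in place of butyl or propyl on the sulfur changes this read-out.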